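The compounds below may be only part of what the source reports. "The series", "measured", "known", "first", "only" and "open" are said of these compounds alone.

Of the compounds shown here, three of one shared core have been read in an ADME assay on MT4 cells (Homo sapiens) for cytotoxicity, read by MTT assay; a lower number here means that less compound is tolerated, a higher number that more compound is tolerated. Compound 1 `Cc1cc(C)cc(S(=O)(=O)c2c(C(=O)NCc3cccc(F)c3F)[nH]c3ccc(Cl)cc23)c1` reaches only the limit of this assay, giving > 51100 nM; this is a limit, not a number. Compound 2 `Cc1cc(C)cc(S(=O)(=O)c2c(C(=O)NC(C)C(=O)NC(C)c3ccccc3)[nH]c3ccc(Cl)cc23)c1` gives 21700 nM in this assay, and compound 3 `Cc1cc(C)cc(S(=O)(=O)c2c(C(=O)NCC(=O)NC(C)c3ccccc3F)[nH]c3ccc(Cl)cc23)c1` gives 23000 nM. Among the measured compounds shown here, the one step that can be followed in this assay runs an at least 2.2-fold lower number from compound 1 to compound 3 (0.34 log units; beyond the scatter). Compound 2 stands with the two numbers that are not limits: its value and that of compound 3 lie within the usual scatter of each other, while the remaining value is the limit of compound 1 (the limit of > 51100 nM in this assay, at which 1 of the 3 values shown sits).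

Compound 4 `Cc1cc(C)cc(S(=O)(=O)c2c(C(=O)NC(C)C(=O)NC(C)c3ccncc3)[nH]c3ccc(Cl)cc23)c1` differs from compound 2 in one place: pyridin-4-yl in place of phenyl on a saturated chain carbon bound to an amide-type nitrogen and a saturated chain carbon. For the measured compounds named here, no measured step swaps one aromatic ring for another at this position; the only step followed alters a different part of the chain, so it gives no direct guide. Without such a precedent, the step from compound 2 to compound 4 in this assay is expected to be a 1.2-fold higher number from compound 2 to compound 4 (0.08 log units; within the scatter), which is within the scatter and in no clear direction. Compound 4 is therefore estimated to give 26000 nM in this assay, with a range from 12000 nM to 55000 nM.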

Compound 4, half-maximal cytotoxic concentration: 21900 nM
Compound 4: the middle estimate sits 1.2-fold (0.07 log units) above what was measured, and the stated range covers the measured number.
By their numbers in this assay, from the lowest: compounds 2, 4 and 3 (each within the scatter of the next). At a limit, above all of these: compound 1.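

In this assay, pyridin-4-yl in place of phenyl on a saturated chain carbon bound to an amide-type nitrogen and a saturated chain carbon gives a 1.0-fold higher number from compound 2 to compound 4 (0.00 log units; within the scatter). Among the compounds shown here, this is the first exchange of one aromatic ring for another at this position that can be followed, and it shows that a ring nitrogen, with the one hydrogen-bond acceptor counted for pyridin-4-yl and none for phenyl, leaves the number within the scatter in this pair. Nothing at hand gives a reason why the number stays in place.

What the compounds shown leave open is how far this holds, since the position is covered by a single pair, and whether pyridin-3-yl, a phenyl ring carrying an amine or a carboxylic acid, or a longer chain in place of 1-phenylethyl would read the same way. As far as these compounds go, it also remains open whether the same ring exchange would read alike in the chain of compound 3, where the 2-fluorophenyl ring stands in this place.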